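Three Inactive Amides and an Unmeasured Benzyl Cousin

The source may report more compounds than this note shows. Statements on the series, on what has been measured and on what is new or still open speak of the compounds shown alone.

Three compounds sharing one core were tested in a functional assay on HeLa cells (Homo sapiens) for cytotoxicity, read by MTT assay, with a stated time of 24 h; a lower number here means a stronger inhibitor, a higher number a weaker inhibitor. Compound 1 `C=CC1=C(C(=O)NCc2ccc(Cl)cc2)C(c2ccc(OC)cc2)OC1` carries a 4-chlorobenzyl group on its amide nitrogen. Compound 2 `C=CC1=C(C(=O)Nc2ccccc2OC)C(c2ccc(OC)cc2)OC1` carries a 2-methoxyphenyl group there, and compound 3 `C=CC1=C(C(=O)NCC(C)C)C(c2ccc(OC)cc2)OC1` an isobutyl group.

In this assay compound 1 gives > 100000 nM, which is a limit of the assay rather than a number. In this assay compound 2 likewise gives > 100000 nM, again a limit. In this assay compound 3 also gives only a limit, > 100000 nM. Compound 3 therefore stands with the other two at the limit of > 100000 nM in this assay, at which 3 of the 3 values shown sit, and none of the three can be ranked against another.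

The three steps among them, a step that the two limits leave unreadable from compound 1 to compound 2, a step that the two limits leave unreadable from compound 1 to compound 3 and a step that the two limits leave unreadable from compound 2 to compound 3, are all unreadable for the same reason, so they give no direction.

Compound 4 `C=CC1=C(C(=O)NCc2ccccc2)C(c2ccc(OC)cc2)OC1` is the untested member. It differs from compound 3 by phenyl in place of isopropyl on a saturated chain carbon bound to an amide-type nitrogen. Because compound 1, which also carries a benzyl-type group, sits at the limit of > 100000 nM in this assay, at which 3 of the 3 values shown sit, compound 4 is expected to show no step beyond the scatter, a step that the limit leaves unreadable from compound 3 to compound 4. In this assay compound 4 is estimated at 150000 nM, within a range from 50000 nM to 500000 nM, most likely reported again as a limit.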

Compound 4, half-maximal inhibitory concentration: > 100000 nM
Compound 4 was reported as a limit (the forecaster's own chance of this, stated with the estimate: 85%); the middle value lies beyond the limit too.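

In this assay compound 4 gives > 100000 nM, again a limit of the assay and not a number. Its steps to compound 1, compound 2 and compound 3 therefore cannot be read, and all four compounds stand together: the limit of > 100000 nM in this assay, at which 4 of the 4 values shown sit.

The compounds shown leave open whether any group on the amide nitrogen of the shared core can give a measurable value in this assay.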